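This account rests on a few compounds, and the source may have more. Where it says the series, first, only, none or still open, it means among the compounds named here.

Compound 1 `O=C(CCCCCC(=O)Nc1ccc(O)c(C(=O)Nc2ccccc2)c1)NO`: 14600 nM
Compound 2 `O=C(CCCCCC(=O)Nc1ccc(O)c(C(=O)Nc2ccc(F)c(F)c2)c1)NO`: 70100 nM

In a functional assay on A549 cells (Homo sapiens) for antiproliferative activity, read by MTT assay, with a stated time of 48 h (on this read-out higher numbers stand for weaker inhibition and lower numbers for stronger inhibition), compound 1 gives 14600 nM, the lower of the two numbers. Compound 3 `C#Cc1cccc(NC(=O)c2cc(NC(=O)CCCCCC(=O)NO)ccc2O)c1` differs from it by ethynyl in place of hydrogen on an aromatic carbon, turning phenyl into 3-ethynylphenyl. Within the data shown here, the one measured step that bears on this also changes that phenyl, here to 3,4-difluorophenyl: a 4.8-fold higher number from compound 1 to compound 2 (0.68 log units; beyond the scatter), a modest step. A single step with a different group is a thin guide, so a smaller rise of the same direction is expected, described as an estimated 1.7-fold higher number from compound 1 to compound 3 (0.23 log units; within the scatter). For compound 3 the estimated value is 25000 nM, with an expected range from 8000 nM to 80000 nM.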

Compound 3, half-maximal inhibitory concentration: 76200 nM
Estimate against measurement, compound 3: 3.0-fold (0.48 log units) below, and the stated range covers the measured number.
By their numbers in this assay, from the lowest: compound 1; then compounds 2 and 3 (each within the scatter of the next).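

In this assay, ethynyl on the phenyl ring gives a 5.2-fold higher number from compound 1 to compound 3 (0.72 log units; beyond the scatter) and so shows that a second, quite different group on this ring also goes with weaker inhibition. The two substituted compounds cannot be told apart, with a 1.1-fold higher number from compound 2 to compound 3 (0.04 log units; within the scatter) lying within the scatter. Nothing measured here explains the loss.

As far as these compounds go, whether any group on this ring can match the plain phenyl of compound 1 stays open. An amine or a carboxylic acid at this place could answer that.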